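Urea nitrogen substituents on the shared core

A few compounds are considered here, and "the series" means these few. Any claim that something is new, unique, unknown or untested is made for them only; others in the source may bear on it.

Measured in a functional assay on HeLa cells (Homo sapiens), read by MTT assay, with a stated time of 72 h; on this read-out lower numbers stand for stronger inhibition and higher numbers for weaker inhibition:
compound 1 `COc1cc(NC(C)CCCNC(=O)NCc2ccccc2)c2ncccc2c1`: 15000 nM
compound 2 `COc1cc(NC(C)CCCNC(=O)NC2CCCCC2)c2ncccc2c1`: > 100000 nM, a limit of the assay, not a number
compound 3 `COc1cc(NC(C)CCCNC(=O)N(C2CCCCC2)C2CCCCC2)c2ncccc2c1`: 23000 nM

Compound 2 stands only at a limit, (the limit of > 100000 nM in this assay, at which 1 of the 3 values shown sits). Compound 4 `COc1cc(NC(C)CCCNC(=O)NCC2CCCCC2)c2ncccc2c1` differs from compound 2 by cyclohexylmethyl in place of cyclohexyl on an amide-type nitrogen. Among the compounds with values here, two measured steps bear on this. Going from compound 1 to compound 2 gave an at least 6.6-fold higher number from compound 1 to compound 2 (0.82 log units; beyond the scatter), and going from compound 2 to compound 3 gave an at least 4.3-fold lower number from compound 2 to compound 3 (0.63 log units; beyond the scatter). Both steps move away from a cyclohexyl sitting directly on the urea nitrogen, and compound 4 does the same by inserting the one-carbon spacer that the benzyl of compound 1 also carries. A downward step in this assay from compound 2 is therefore expected, roughly an at least 3.3-fold lower number from compound 2 to compound 4 (0.52 log units; beyond the scatter). Compound 4 is estimated at 30000 nM, within 10000 nM to 120000 nM.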

Compound 4, half-maximal inhibitory concentration: > 100000 nM
Compound 4: no number, only a limit; the forecaster's own chance of this, stated with the estimate: 25%; at least 3.3-fold (0.52 log units) between middle value and limit.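

In this assay compound 4 gives > 100000 nM, a limit of the assay and not a number. The spacer alone does not give a readable value: with cyclohexyl in place of phenyl on the saturated chain carbon bound to an amide-type nitrogen, the result is an at least 6.6-fold higher number from compound 1 to compound 4 (0.82 log units; beyond the scatter). The step between compound 2 and compound 4 cannot be read, and the two compounds now sit together at the ceiling: the limit of > 100000 nM in this assay, at which 2 of the 4 values shown sit.

On these data alone, whether a phenethyl group in place of benzyl keeps a readable value stays open. So does whether a second cyclohexylmethyl on the same nitrogen would bring a readable value, as the second cyclohexyl of compound 3 does.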